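Pyrimidine attachment on the sulfonamide nitrogen of compound 3

The source may report more compounds than this note shows. Statements on the series, on what has been measured and on what is new or still open speak of the compounds shown alone.

The series shares one core and varies only the group on the sulfonamide nitrogen. In a functional assay on T47D cells (Homo sapiens) for cytotoxicity, read by sulforhodamine B assay, with a stated time of 48 h (a higher number here means a weaker inhibitor, a lower number a stronger inhibitor), compound 1 `NS(=O)(=O)c1ccc(N/C=C\C(=O)c2cc3ccccc3oc2=O)cc1` gives 109000 nM, compound 2 `Cc1nnc(NS(=O)(=O)c2ccc(N/C=C\C(=O)c3cc4ccccc4oc3=O)cc2)s1` gives 94000 nM, and compound 3 `Cc1cc(C)nc(NS(=O)(=O)c2ccc(N/C=C\C(=O)c3cc4ccccc4oc3=O)cc2)n1` gives 62200 nM. Compound 3 carries the lowest number of the three, but the steps to it, a 1.8-fold lower number from compound 1 to compound 3 (0.24 log units; within the scatter) and a 1.5-fold lower number from compound 2 to compound 3 (0.18 log units; within the scatter), and the step of a 1.2-fold lower number from compound 1 to compound 2 (0.06 log units; within the scatter) all sit within the scatter, so no ordering among compounds 1, 2 and 3 can be read from these numbers.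

Compound 4 `Cc1cc(NS(=O)(=O)c2ccc(N/C=C\C(=O)c3cc4ccccc4oc3=O)cc2)nc(C)n1` differs from compound 3 only at the sulfonamide nitrogen: 2,6-dimethylpyrimidin-4-yl in place of 4,6-dimethylpyrimidin-2-yl on a sulfonamide nitrogen. The two have the same atoms, joined differently. For the measured compounds named here, none of the measured steps moves a pyrimidine from one attachment point to another; the nearest comparisons are the swaps of the whole nitrogen substituent, which gave a 1.2-fold lower number from compound 1 to compound 2 (0.06 log units; within the scatter), a 1.8-fold lower number from compound 1 to compound 3 (0.24 log units; within the scatter) and a 1.5-fold lower number from compound 2 to compound 3 (0.18 log units; within the scatter), each within the scatter. Changes at this position have therefore left this assay essentially flat so far, and the step of a 1.0-fold higher number from compound 3 to compound 4 (0.02 log units; within the scatter) is expected to stay within the scatter as well. Compound 4 is accordingly estimated at 65000 nM, with a range of 30000 nM to 140000 nM.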

Compound 4, half-maximal inhibitory concentration: 100000 nM
Beside the measured number, compound 4's estimate is 1.5-fold (0.19 log units) below it, within the range that was stated.
By their numbers in this assay, from the lowest: compounds 3, 2, 4 and 1 (each within the scatter of the next).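

Moving the attachment point of the pyrimidine on the sulfonamide nitrogen is the first change in this series that keeps the atoms of the substituent and alters only how they are joined, and in this assay it gives a 1.6-fold higher number from compound 3 to compound 4 (0.21 log units; within the scatter) and so does not separate the two isomers. The other new steps, a 1.1-fold higher number from compound 2 to compound 4 (0.03 log units; within the scatter) and a 1.1-fold lower number from compound 1 to compound 4 (0.04 log units; within the scatter) also lie within the scatter, which means that compounds 1, 2, 3 and 4 cannot be ordered and that the flat picture at this position now extends from whole-substituent swaps to the attachment point of the pyrimidine. Nothing in the available data bears on a cause for these numbers.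

Going by these compounds, whether an open-chain group on the sulfonamide nitrogen, such as an acetyl or a longer alkyl chain, would move the number beyond the scatter stays open. On these data alone, it is also open whether a pyrimidin-2-yl or pyrimidin-4-yl without the two methyl groups would stay as flat as compound 3 and compound 4 in this assay or would break from them.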